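The source may report more compounds than this note shows. Statements on the series, on what has been measured and on what is new or still open speak of the compounds shown alone.

Compound 1 `Nc1ccc(-c2cc(=O)c3c(N)c(F)c(Br)c(F)c3o2)cc1F`: in a functional assay on HeLa cells (Homo sapiens) for cytotoxicity, read by neutral red uptake, with a stated time of 3 days (a higher number here means a weaker inhibitor, a lower number a stronger inhibitor), compound 1 gives > 100000 nM, which is a limit of the assay rather than a number.
Compound 2 `CN(C)c1c(F)c(N)c2c(=O)cc(-c3ccc(N)c(F)c3)oc2c1F`: in this assay compound 2 gives > 100000 nM, likewise a limit of the assay.

Among the measured compounds shown here, compound 1 therefore stands only at a limit, and the one other value shown is a limit as well, so no order between the two can be read. For the measured compounds named here, the single measured step, a step that the two limits leave unreadable from compound 1 to compound 2, cannot be sized, since both of its ends sit at the limit of > 100000 nM in this assay, at which 2 of the 2 values shown sit.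

Compound 3 `CN(C)CC(=O)OCc1c(F)c(N)c2c(=O)cc(-c3ccc(N)c(F)c3)oc2c1F` has not yet been measured. It differs from compound 1 by ((((dimethylamino)methyl)carbonyl)oxy)methyl in place of bromo on an aromatic carbon. Going by the values given here, no measured step bears directly on this change; the one available step leaves its size unreadable, and the data give no ground to expect a gain beyond the scatter. Compound 3 is therefore expected to sit at or near the limit too, with the step of a number no higher from compound 1 to compound 3 (the limit leaves the size open) estimated to be small. For compound 3 the estimate in this assay is 100000 nM, with a range from 30000 nM to 300000 nM.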

Compound 3, half-maximal inhibitory concentration: 9200 nM
For compound 3 the middle estimate is 11-fold (1.04 log units) above the measured one, and the stated range ends above it.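

At the aromatic carbon ortho to two fluoro groups, the change shows that this position can move the read-out in this assay: ((((dimethylamino)methyl)carbonyl)oxy)methyl in place of bromo gives an at least 10-fold lower number from compound 1 to compound 3 (1.03 log units; beyond the scatter), and the same group in place of dimethylamino gives an at least 10-fold lower number from compound 2 to compound 3 (1.03 log units; beyond the scatter). Among the compounds shown here, the earlier pair could show no difference at this carbon, and compound 3 now gives the only value that is not a limit: the limit of > 100000 nM in this assay, at which 2 of the 3 values shown sit. The step between bromo and dimethylamino remains unreadable.

The new group enters as a whole, so the compounds shown leave open whether its carbonyl, its oxygen link or its terminal dimethylamino goes with the step. From the compounds shown here alone, how a hydroxymethyl group, a carboxylic acid or a longer amine chain at this carbon would read in this assay also remains open.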